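The source may report more compounds than this note shows. Statements on the series, on what has been measured and on what is new or still open speak of the compounds shown alone.

Working notes on the series. Compound 1 `Cn1nnnc1SCC(=O)Nc1ccc(-c2nc(-c3ccccc3)c(-c3ccccc3)n2C)cc1` gives 55.9% in a functional assay on MCF7 cells (Homo sapiens) for cytotoxicity, read by MTT assay, with a stated time of 24 h, tested at 6.4 ug/mL; a higher number here means a stronger effect of the compound at the concentration tested, a lower number a weaker effect. Compound 2 `Cn1c(-c2ccc(NC(=O)CN3CCN(c4ccccc4)CC3)cc2)nc(-c2ccccc2)c1-c1ccccc1` gives 37.7% in this assay. The step of a number 18.2 percentage points lower from compound 1 to compound 2 (beyond the scatter) is modest. Compound 3 `Cn1c(-c2ccc(NC(=O)CN3CCN(Cc4ccccc4)CC3)cc2)nc(-c2ccccc2)c1-c1ccccc1` gives 23.8% in this assay, and the step of a number 13.9 percentage points lower from compound 2 to compound 3 (beyond the scatter) is likewise modest. On these numbers compound 3 stands lowest of the three, nearest compound 2 and furthest from compound 1. Compound 4 `Cn1c(-c2ccc(NC(=O)CN3CCN(Cc4ccc(Cl)cc4)CC3)cc2)nc(-c2ccccc2)c1-c1ccccc1` is not yet measured; it differs from compound 3 by chloro in place of hydrogen on an aromatic carbon. For the measured compounds named here, neither measured step concerns a chloro-for-hydrogen exchange on an aromatic carbon, so no step bears directly on this change, and the expectation is a step of none beyond the scatter. The expected step is a number 1.2 percentage points higher from compound 3 to compound 4 (within the scatter). Compound 4 is therefore estimated at 25%, with a range of 10% to 42%.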

Compound 4, a percentage reported as activity, at one concentration (the size of the read-out at that concentration, not a potency): 33.4%
For compound 4 the middle estimate is 8.4 percentage points below the measured one, and the stated range covers the measured number.
By their numbers in this assay, from the lowest: compounds 3, 4 and 2 (each within the scatter of the next, the first and the last beyond it); then compound 1.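

Chloro in place of hydrogen on an aromatic carbon, para to a large group, reads as a number 9.6 percentage points higher from compound 3 to compound 4 (within the scatter) in this assay, so this position takes a chloro with no step beyond the scatter. 4-Chlorobenzyl in place of phenyl on the ring amine nitrogen reads as a number 4.3 percentage points lower from compound 2 to compound 4 (within the scatter), whereas the plain benzyl exchange stood beyond the scatter. Open, going by these compounds, is whether a fluoro, a methoxy or a nitrile in the same place would read differently from chloro. Nothing measured on these compounds accounts for this result.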